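A few compounds are considered here, and "the series" means these few. Any claim that something is new, unique, unknown or untested is made for them only; others in the source may bear on it.

Compound 1 `COc1cc(-c2nnc(SCc3ccc(Cl)cc3)o2)ccc1O` gives 11100 nM in a functional assay on cells (T-cell, Mus musculus, strain BALB/c) for inhibition, read by MTT assay, with stated times of 24 h and 72 h; on this read-out lower numbers stand for stronger inhibition and higher numbers for weaker inhibition.
Compound 2 `COc1cc(-c2nnc(SCc3ccccc3Br)o2)ccc1O` gives 17800 nM in this assay.
Compound 3 `COc1cc(-c2nnc(SCc3ccc(F)cc3)o2)ccc1O` gives 8190 nM in this assay.

Among these three numbers compound 1 stands second highest: the step of a 1.4-fold lower number from compound 1 to compound 3 (0.13 log units; within the scatter) and the step of a 1.6-fold higher number from compound 1 to compound 2 (0.21 log units; within the scatter) both lie within the scatter. Compound 4 `COc1cccc(CSc2nnc(-c3ccc(O)c(OC)c3)o2)c1` has not yet been measured. It differs from compound 1 in one place: 3-methoxyphenyl in place of 4-chlorophenyl on a saturated chain carbon bound to a sulfur. The measured steps that swap the same group are a 1.6-fold higher number from compound 1 to compound 2 (0.21 log units; within the scatter) and a 2.2-fold lower number from compound 2 to compound 3 (0.34 log units; beyond the scatter), each small and at most modest. Replacing this group has so far moved the numbers little, so no step beyond the scatter is expected here. Compound 4 is therefore estimated at 11000 nM, with a range of 5000 nM to 25000 nM. The expected step is a 1.0-fold lower number from compound 1 to compound 4 (0.00 log units; within the scatter).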

Compound 4, half-maximal inhibitory concentration: 7410 nM
The estimate for compound 4 lay 1.5-fold (0.17 log units) above the measured number, within the range that was stated.
By their numbers in this assay, from the lowest: compounds 4, 3, 1 and 2 (each within the scatter of the next, the first and the last beyond it).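

Putting 3-methoxyphenyl on the saturated chain carbon bound to a sulfur shows that this position accepts a ring with no halogen and with a hydrogen-bond acceptor: a 1.5-fold lower number from compound 1 to compound 4 (0.18 log units; within the scatter) and a 1.1-fold lower number from compound 3 to compound 4 (0.04 log units; within the scatter) both stay within the scatter. Only a 2.4-fold lower number from compound 2 to compound 4 (0.38 log units; beyond the scatter) goes beyond it, and it is modest, so compound 2 again stands apart from the others. Nothing available explains these numbers.

On these data alone, whether this position would also accept an amine, a carboxylic acid or a longer chain in place of the phenyl ring remains open. So does whether 4-methoxyphenyl would give a similar number.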